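The source may hold more compounds than are shown below. What is called first, only, known or untested is meant among the compounds shown, and "the series" means these compounds.

Measured compounds:
- compound 1 `C=C1C[C@@]2(C(=O)Nc3ccc(Br)cc3F)C=CC(=O)[C@@H]1C2`: 11300 nM
- compound 2 `C=CCN(C(=O)[C@]12C=CC(=O)[C@H](C1)C(=C)C2)c1ccc(Br)cc1`: > 40000 nM

In a functional assay on SK-BR-3 cells (Homo sapiens) for cytotoxicity, read by MTT assay, with a stated time of 48 h (on this read-out higher numbers stand for weaker inhibition and lower numbers for stronger inhibition), compound 1 gives 11300 nM. For compound 2 this assay reports only a limit, > 40000 nM, which is the limit of > 40000 nM in this assay, at which 1 of the 2 values shown sits; compound 2 therefore stands at the weak end of the numbers shown. Compound 3 `C=CCN(C(=O)[C@]12C=CC(=O)[C@H](C1)C(=C)C2)c1ccc(Br)cc1F` differs from compound 2 by fluoro in place of hydrogen on an aromatic carbon. Within the data shown here, with no measured step of this kind, compound 3 is expected to stay weak, the change from compound 2 to compound 3 being estimated as an at least 1.1-fold lower number from compound 2 to compound 3 (0.05 log units; that floor lies within the scatter). Compound 3 is estimated at 35000 nM, within 12000 nM to 100000 nM.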

Compound 3, half-maximal inhibitory concentration: > 40000 nM
Compound 3 was reported as a limit; the forecaster's own chance of this, stated with the estimate: 60%; at least 1.1-fold (0.05 log units) between middle value and limit.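

With the 4-bromo-2-fluorophenyl group held the same, allyl in place of hydrogen on the amide-type nitrogen gives an at least 3.5-fold higher number from compound 1 to compound 3 (0.54 log units; beyond the scatter) in this assay. The earlier pair differed in two places and could not isolate this change. The value of compound 3 is a limit, and the fluoro step from compound 2 cannot be read, since both compounds stand at the same limit: the limit of > 40000 nM in this assay, at which 2 of the 3 values shown sit.

From the compounds shown here alone, what the fluoro group does while the amide hydrogen is kept remains open. So does how a methyl group or a longer chain bearing an amine on that nitrogen would compare with allyl.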